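This account rests on a few compounds, and the source may have more. Where it says the series, first, only, none or still open, it means among the compounds named here.

Three compounds have been measured:
compound 1, `CC(C)CCn1ccc(-c2ccc(Oc3ccncc3)cc2)c(C#N)c1=O`: 550 nM
compound 2, `Cc1cc(Oc2ccc(-c3ccn(CCC(C)C)c(=O)c3C#N)cc2)ccn1`: 447 nM
compound 3, `CCCCn1ccc(-c2ccc(Oc3cccnc3C)cc2)c(C#N)c1=O`: 347 nM

All three were tested in a functional assay on CHO cells for positive allosteric modulation of metabotropic glutamate receptor 2 (Homo sapiens), read by scintillation counting and GTPgammaS binding, with a stated time of 30 min; a higher number here means that more compound is needed for the effect, a lower number that less compound is needed. Compound 1 and compound 2 differ in one place only: methyl in place of hydrogen on an aromatic carbon. That change gave a 1.2-fold lower number from compound 1 to compound 2 (0.09 log units; within the scatter), so the added methyl made no difference that the assay can resolve. Compound 3 is built from the same atoms as compound 1, joined differently; the difference between the two cores is not broken down here. The three values lie within the usual scatter of one another, so none of the three compounds can be called more or less potent than the others.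

Compound 4, `CCCCn1ccc(-c2ccc(Oc3ccc(C)nc3C)cc2)c(C#N)c1=O`, has not yet been measured. It differs from compound 3 by methyl in place of hydrogen on an aromatic carbon. Going by the values given here, this is the same kind of change as the one from compound 1 to compound 2, but at a different place: in compound 2 the methyl sits meta to a large group, whereas in compound 4 it sits meta to a methyl group and para to a large group. A similarly small step is expected, a 1.2-fold lower number from compound 3 to compound 4 (0.06 log units; within the scatter), because the same kind of change gave a 1.2-fold lower number from compound 1 to compound 2 (0.09 log units; within the scatter). Compound 4 is therefore expected to give about 300 nM, with a likely range from 120 nM to 750 nM.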

Compound 4, half-maximal effective concentration: 138 nM
Beside the measured number, compound 4's estimate is 2.2-fold (0.34 log units) above it; the range from low to high includes it.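

In this assay, turning the 2-methylpyridin-3-yl group of compound 3 into the 2,6-dimethylpyridin-3-yl group of compound 4 gave a 2.5-fold lower number from compound 3 to compound 4 (0.40 log units; beyond the scatter), so here a single added methyl produced a real, if modest, change in the number. Set beside the earlier methyl step, the new step cannot be told apart from it, even though only the new one can be resolved on its own: the same change on two cores in this assay, a 1.2-fold lower number (0.09 log units; within the scatter) from compound 1 to compound 2 and a 2.5-fold lower number (0.40 log units; beyond the scatter) from compound 3 to compound 4, 2.0-fold (0.31 log units) apart, within the scatter of two such steps This shows that, for these two pairs, the size of the effect does not measurably depend on the core, but it does not show that the effect carries over unchanged, as the methyl also sits at a different place on the ring in each pair and two steps are too few to separate core from position or to set a rule for the series.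

Still open, from the compounds shown here alone, is what an ethyl, a methoxy or a chlorine would do in place of the new methyl of compound 4. Also open, going by these compounds, is whether the 2,6-dimethylpyridin-3-yl group would give a similar step if the butyl chain of compound 4 were replaced by a longer chain or by one carrying an amine.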